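This account rests on a few compounds, and the source may have more. Where it says the series, first, only, none or still open, it means among the compounds named here.

Working notes on the series. In a functional assay on CHO cells for antagonist activity at sphingosine 1-phosphate receptor 2 (Homo sapiens), read by GTPgammaS binding (on this read-out lower numbers stand for stronger inhibition and higher numbers for weaker inhibition), compound 1 `CCOc1cc2[nH]c(Cc3nn(CC(=O)N4CCOCC4)c(=O)c4ccccc34)nc2cc1Cl` gives 22 nM. For the measured compounds named here, compound 2 `CCOc1cc2[nH]c(Cc3nn(CC(=O)O)c(=O)c4ccccc34)nc2cc1Cl` gives 109 nM in this assay, the highest of the three numbers measured so far; compound 3 `CC(C)(C(=O)O)c1nn(Cc2cn3cc(OCC4CC4)c(Cl)cc3n2)c2ccccc2c1=O` gives 105 nM, which sits within the scatter of the number for compound 2. Going by the values given here, the one single-point step available, a 5.0-fold higher number from compound 1 to compound 2 (0.70 log units; beyond the scatter), concerns the hydroxy in place of morpholin-4-yl on a carbonyl carbon and does not touch the part of the molecule changed here.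

Compound 4 `O=C(O)Cn1nc(Cc2nc3cc(Cl)c(OCC4CC4)cc3[nH]2)c2ccccc2c1=O` differs from compound 2 by cyclopropyl in place of methyl on a saturated chain carbon bound to an oxygen on an aromatic ring. Among the compounds with values here, no measured step bears on this change; the only guide is that compound 3, which carries a cyclopropylmethoxy group, gives a number close to that of compound 2, but compound 3 differs from compound 2 in more than one place, so this is not a clean comparison. The step from compound 2 to compound 4 is therefore expected to be a 1.2-fold lower number from compound 2 to compound 4 (0.08 log units; within the scatter), not beyond the scatter in either direction. Compound 4 is estimated at 90 nM in this assay, in the range 35 nM to 250 nM.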

Compound 4, half-maximal inhibitory concentration in the sphingosine 1-phosphate receptor 2 assay: 25 nM
For compound 4 the middle estimate is 3.6-fold (0.56 log units) above the measured one, and the stated range ends above it.
By their numbers in the sphingosine 1-phosphate receptor 2 assay, from the lowest: compounds 1 and 4 (each within the scatter of the next); then compounds 3 and 2 (each within the scatter of the next).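

For the compounds shown here, the ether chain is not a silent position: in the sphingosine 1-phosphate receptor 2 assay, cyclopropyl in place of methyl on a saturated chain carbon bound to an oxygen on an aromatic ring gives a 4.4-fold lower number from compound 2 to compound 4 (0.64 log units; beyond the scatter), a gain in inhibition that the earlier compounds could not show, since their only step lay at the carbonyl carbon. This gain arises with the carboxylic acid kept in place, so that group alone does not fix the number in this assay. In a physicochemical assay for solubility, measured as thermodynamic solubility, at pH 7.4 (on this read-out higher numbers stand for higher solubility and lower numbers for lower solubility), compound 2 gives 917 ug/mL and compound 4 gives 395 ug/mL so the same change does not come free there: the measured solubility of compound 2, 917 ug/mL, and of compound 4, 395 ug/mL, a 2.3-fold lower number (0.37 log units; beyond the scatter)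

Whether the step from ethoxy to cyclopropylmethoxy adds to the step at the carbonyl carbon stays open, as no compound shown joins cyclopropylmethoxy with the morpholin-4-yl amide. Also open, from the compounds shown here alone, is whether a cyclobutyl group or a longer chain on the same carbon would lower the inhibition number further, and at what cost in solubility.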